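The source may hold more compounds than are shown below. What is called first, only, known or untested is meant among the compounds shown, and "the series" means these compounds.

Working notes on the series. Compound 2 `CC(C)=CCC1Cc2c(OCCCNC(=O)c3ccco3)cc(=O)n(CCCO)c2CC1(C)C` is measured in a functional assay on PANC-1 cells (Homo sapiens) for inhibition, read by MTT assay, with a stated time of 24 h, tested at 10 uM (a lower number here means less inhibition, a higher number more inhibition at the concentration tested (going by the name of the read-out)), at 4.3%, the second highest of the three numbers, though only compound 1 stands apart from it. Compound 1 `CC(C)=CCC1Cc2c(OCCCNS(=O)(=O)c3ccc([N+](=O)[O-])cc3)cc(=O)n(CCCO)c2CC1(C)C` gives 17.3%, and compound 3 `COc1ccc(OCCCOc2cc(=O)n(CCCO)c3c2CC(CC=C(C)C)C(C)(C)C3)cc1` gives 4.1%. Two steps are recorded: a number 13 percentage points lower from compound 1 to compound 2 (beyond the scatter), and a number 0.2 percentage points lower from compound 2 to compound 3 (within the scatter).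

Compound 4 `CC(C)=CCC1Cc2c(OC(=O)Nc3ccc(F)cc3F)cc(=O)n(CCCO)c2CC1(C)C` has not been measured. ((2,4-difluorophenyl)carbamoyl in place of 3-(((furan-2-yl)carbonyl)amino)propyl on an oxygen on an aromatic ring). The change reaches the oxygen on the aromatic ring itself, so neither recorded step maps onto it closely. Both steps alter what hangs from that oxygen: one moved the read-out beyond the scatter, the other did not, and the numbers for compound 2 and compound 3 sit at the low end of the range seen. With the chain removed and a carbamoyl group placed directly on that oxygen, no strong shift is expected in this assay; the estimate for the step from compound 2 to compound 4 is a number 3.7 percentage points higher from compound 2 to compound 4 (within the scatter), within the scatter. Within the data shown here, compound 4 is therefore expected near 8%, in a range from 0% to 25%, the width reflecting that the change has no close precedent among the measured compounds.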

Compound 4, a percentage reported as inhibition, at one concentration (the size of the read-out at that concentration, not a potency): 0%
The estimate for compound 4 lay 8 percentage points above the measured number; the range from low to high includes it.
By their numbers in this assay, from the lowest: compounds 4, 3 and 2 (each within the scatter of the next); then compound 1.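

The step of a number 4.3 percentage points lower from compound 2 to compound 4 (within the scatter) shows, in this assay, that the oxygen on the aromatic ring can carry a (2,4-difluorophenyl)carbamoyl group directly, without the 3-(((furan-2-yl)carbonyl)amino)propyl chain, and the read-out stays level with that of compound 2. Among these compounds, a carbamoyl link on this oxygen therefore joins the furan amide and the 4-methoxyphenoxy chain end as changes that leave the number within the scatter, while the only step beyond the scatter remains a number 13 percentage points lower from compound 1 to compound 2 (beyond the scatter). Nothing available explains why the read-out stays at this level.

Still open, as far as these compounds go, is whether a longer chain between the oxygen and the (4-nitrophenyl)sulfonyl amine would alter the read-out. From the compounds shown here alone, it is equally open whether a free amine or a carboxylic acid at the end of the propyl chain would do so.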